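A few compounds are considered here, and "the series" means these few. Any claim that something is new, unique, unknown or untested is made for them only; others in the source may bear on it.

Compound 2 `O=C(Nc1ccc(Sc2nc3ccccc3s2)cc1)c1ccccc1` is one of two compounds tested in an assay on isolated protein for inhibition of thiosulfate sulfurtransferase (Homo sapiens), with a stated time of 60 min, in the absence of a further agent; on this read-out lower numbers stand for stronger inhibition and higher numbers for weaker inhibition. In this assay compound 2 reaches only the limit of the assay, > 100000 nM, and no number. Compound 1 `O=C(Nc1ccc(Sc2nc3ccccc3s2)cc1)c1cc(Br)cc(Br)c1` likewise stops at the limit of the assay in this assay, giving > 100000 nM. The step that the two limits leave unreadable from compound 1 to compound 2 cannot be read because both values sit at the boundary described by the limit of > 100000 nM in this assay, at which 2 of the 2 values shown sit. Compound 3 `O=C(Nc1ccc(Sc2nc3ccccc3s2)cc1)c1cccc(Br)c1O` differs from compound 2 by a single change: 3-bromo-2-hydroxyphenyl in place of phenyl on a carbonyl carbon. No measured step bears on this change, so nothing shown points in either direction. The expected step that the limit leaves unreadable from compound 2 to compound 3 is therefore none beyond the scatter, and compound 3 is estimated at 120000 nM, within a range from 30000 nM to 500000 nM, most likely reported again only as a limit.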

Compound 3, half-maximal inhibitory concentration: > 100000 nM
Compound 3 was reported as a limit (the forecaster's own chance of this, stated with the estimate: 80%); the middle value is on the limit's open side.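

For the compounds shown here, no step among compound 1, compound 2 and compound 3 can be read in this assay, where all three stop at a limit: the limit of > 100000 nM in this assay, at which 3 of the 3 values shown sit. Still open is whether any of these compounds inhibits the enzyme, and whether the group on the carbonyl carbon affects inhibition.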